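The compounds below may be only part of what the source reports. "The series", "measured", "known", "first", "only" and "open" are said of these compounds alone.

In an assay on isolated protein for inhibition of malate dehydrogenase, mitochondrial (Sus scrofa), with stated times of 45 min and 30 min (on this read-out higher numbers stand for weaker inhibition and lower numbers for stronger inhibition), compound 1, `O=S(=O)(Nc1ccc(-c2nc3ccccc3o2)cc1)c1ccc(F)c(C(F)(F)F)c1`, gives > 63000 nM, which is a limit of the assay and not a measured number. Compound 2, `O=S(=O)(Nc1ccc2oc(-c3ccccc3)nc2c1)c1ccccc1C(F)(F)F`, gives > 63000 nM in this assay, again a limit. Compound 3, `O=S(=O)(Nc1ccc2oc(-c3ccccc3)nc2c1)c1ccccc1Cl`, gives > 63000 nM in this assay, also a limit. Compound 3 therefore stands where the whole set stands, at the limit of > 63000 nM in this assay, at which 3 of the 3 values shown sit, and nothing separates it from the other two on the numbers shown. For the measured compounds named here, the single step that can be traced, a step that the two limits leave unreadable from compound 2 to compound 3, lies between two limits and its size cannot be read.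

Compound 4, `O=S(=O)(Nc1ccc2oc(-c3ccccc3)nc2c1)c1ccc(O)cc1`, differs from compound 3 by 4-hydroxyphenyl in place of 2-chlorophenyl on a sulfonyl sulfur. Going by the values given here, no measured step touches this change, since the only step recorded involves chloro in place of trifluoromethyl and is itself unreadable. What the data do offer is the limit of > 63000 nM in this assay, at which 3 of the 3 values shown sit, which places every measured value at the same limit, so no movement beyond the scatter has been observed anywhere in this small set. On that basis the step of a number no higher from compound 3 to compound 4 (the limit leaves the size open) is expected to stay within what the assay can report rather than produce a readable gain. Compound 4 is accordingly estimated at 63000 nM in this assay, with an expected range from 15000 nM to 250000 nM, and a strong likelihood that only a limit is reported.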

Compound 4, half-maximal inhibitory concentration: > 63000 nM
Compound 4 ended at the assay's limit; the forecaster's own chance of this, stated with the estimate: 75%; the middle value lies on the limit itself.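

No new step can be read: compound 3 and compound 4 both end at a limit of the assay, so the change from 2-chlorophenyl to 4-hydroxyphenyl on a sulfonyl sulfur has no readable size, and the set stays where it stood: the limit of > 63000 nM in this assay, at which 4 of the 4 values shown sit. The compounds shown leave open how strongly any of the four inhibits the enzyme, and whether any change among them shifts that.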